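Fluoro to Nitro in a Small Antiproliferative Series

The source may report more compounds than this note shows. Statements on the series, on what has been measured and on what is new or still open speak of the compounds shown alone.

Measured in a functional assay on HepG2 cells (Homo sapiens) for antiproliferative activity, read by MTT assay, with a stated time of 48 h; on this read-out higher numbers stand for weaker inhibition and lower numbers for stronger inhibition:
- compound 1 `CC(=O)N1N=C(c2ccc3ccccc3c2)OC1c1ccccc1Br`: 3.98 ug/mL
- compound 2 `CC(=O)N1N=C(c2ccc3ccccc3c2)OC1c1ccc(Cl)cc1`: 1.88 ug/mL
- compound 3 `CC(=O)N1N=C(c2ccc3ccccc3c2)OC1c1ccc(F)cc1`: 1.82 ug/mL

Compound 3 carries the lowest of the three numbers, but it cannot be separated from compound 2, as a 1.0-fold lower number from compound 2 to compound 3 (0.01 log units; within the scatter) shows. Both lie clear of compound 1, with a 2.2-fold lower number from compound 1 to compound 3 (0.34 log units; beyond the scatter) and a 2.1-fold lower number from compound 1 to compound 2 (0.33 log units; beyond the scatter), which are modest steps.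

The next compound is compound 4 `CC(=O)N1N=C(c2ccc3ccccc3c2)OC1c1ccc([N+](=O)[O-])cc1`, which has nitro in place of fluoro on an aromatic carbon. It keeps the shared core, and the change reads 4-fluorophenyl to 4-nitrophenyl.

The closest evidence is the swap at this same site, where a 1.0-fold lower number from compound 2 to compound 3 (0.01 log units; within the scatter) stayed within the scatter. The two steps from compound 1 are less direct, since each replaces 2-bromophenyl and so alters more than the group at this site. Within the data shown here, no measured compound carries nitro, so the data give no direction for this change, and a surprise of modest size remains possible. In this assay, the expected result is a 1.2-fold higher number from compound 3 to compound 4 (0.08 log units; within the scatter), which would be no clear step beyond the scatter. For compound 4 the estimated value is 2.2 ug/mL, with an expected range of 0.9 ug/mL to 5.5 ug/mL.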

Compound 4, half-maximal inhibitory concentration: 8.1 ug/mL
Compound 4: the middle estimate sits 3.7-fold (0.57 log units) below what was measured, outside the stated range (above it).
By their numbers in this assay, from the lowest: compounds 3 and 2 (each within the scatter of the next); then compound 1; then compound 4.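

In this assay, the group at this site turns out to matter: fluoro and chloro could not be told apart, but nitro separates from both, with a 4.5-fold higher number from compound 3 to compound 4 (0.65 log units; beyond the scatter) and a 4.3-fold higher number from compound 2 to compound 4 (0.63 log units; beyond the scatter) as the steps. The change also carries compound 4 past the 2-bromophenyl compound, as a 2.0-fold higher number from compound 1 to compound 4 (0.31 log units; beyond the scatter) shows, which makes compound 4 the weakest inhibitor of the four, since its steps to all three others lie beyond the scatter. No measurement at hand bears on why nitro behaves differently from the two halogens at this place.

The compounds shown hold only fluoro, chloro and nitro at this place, so it remains open whether an amine, a nitrile or a carboxylic acid there would stay with the halogens or go with nitro. Bromo appears only in compound 1, so the effect of that group cannot be told apart from the effect of where it sits on the ring.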